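Adding a chloro group to compound 2

The compounds below may be only part of what the source reports. "The series", "measured", "known", "first", "only" and "open" are said of these compounds alone.

- Compound 1 `COc1ccc2c(c1)C(=O)C(CN1CCCCC1)CC2` with 10.5 h
- Compound 2 `CN(C)CC1Cc2ccccc2C1=O` with 0.167 h
- Compound 3 `Cc1ccc2c(c1)C(=O)C(CN(C)C)C2` with 0.233 h

All three half-lives come from a physicochemical assay for pharmacokinetics, read by HPLC, at pH 7.5, tested at 250 uM (a lower number here means that the compound disappears faster, a higher number that the compound lasts longer), and they fall into two groups. Compound 2 sits at the short-lived end of this small set, within the scatter of compound 3, while compound 1 lasts far longer. Compound 1 differs from compound 2 in more than one place, so the gap between them cannot be read as the result of a single change.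

The unmeasured compound 4 `CN(C)CC1Cc2cc(Cl)ccc2C1=O` is compound 2 with chloro in place of hydrogen on an aromatic carbon. One measured step is of a similar kind, with methyl in place of hydrogen on an aromatic carbon. That step is small, a 1.4-fold higher number from compound 2 to compound 3 (0.14 log units; within the scatter) and lies within the scatter. Among the measured compounds shown here, it is only a single example, and it involves methyl, as no chloro compound has been measured yet. On this evidence, no step beyond the scatter is expected in this assay and no direction can be firmly predicted. The estimated step is a 1.2-fold higher number from compound 2 to compound 4 (0.08 log units; within the scatter) which would stay within the scatter. Compound 4 is expected to show a short half-life near 0.2 h (estimated range 0.1 h to 0.4 h).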

Compound 4, half-life: 0.117 h
Compound 4: middle estimate off by 1.7-fold (0.23 log units), on the high side, and the stated range covers the measured number.
By their numbers in this assay, from the lowest: compounds 4, 2 and 3 (each within the scatter of the next); then compound 1.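

In this assay, chloro in place of hydrogen on an aromatic carbon, meta to a fused ring and para to a fused ring, gives a 1.4-fold lower number from compound 2 to compound 4 (0.15 log units; within the scatter). Among the compounds shown here, this is the first chloro example, and it joins the methyl step, a 1.4-fold higher number from compound 2 to compound 3 (0.14 log units; within the scatter), as a second swap of hydrogen on an aromatic carbon of this short-lived series that stays within the usual variation between repeat measurements, so neither step on its own shows a real shift in half-life. No measurement is available that would explain the size or the direction of the chloro step.

The compounds shown leave open whether a different group on this same aromatic carbon, such as a nitrile or a carboxylic acid, would also stay within the scatter of compound 2. For the compounds shown here, they also leave open which of its several differences from compound 2 goes with the much longer half-life of compound 1, at 10.5 h, since no step changing only one of those places is available.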